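A Methyl Added to a Series Without Measured Activity

This account rests on a few compounds, and the source may have more. Where it says the series, first, only, none or still open, it means among the compounds named here.

Compound 1, `CCOC(=O)[C@@H]1C[C@@]23CN(C)C[C@@H](CCC4=C2[C@H]1CC4=O)C31CC[C@](CC)(OC)OC1`, in a functional assay on MCF7 cells (Homo sapiens) for cytotoxicity, read by MTT assay, with a stated time of 48 h (a lower number here means a stronger inhibitor, a higher number a weaker inhibitor), gives > 40000 nM, which is a limit of the assay and not a number.
Compound 2, `CC[C@@]1(OC)CCC2(CO1)[C@@H]1CCC3=C4[C@H](CC3=O)[C@H](C(=O)OC)C[C@@]42CN(C)C1`, in this assay gives > 40000 nM, again only a limit.
Compound 3, `CCC1=CCC2(CO1)[C@@H]1CCC3=C4[C@H](CC3=O)[C@H](C(=O)OC)C[C@@]42CN(C)C1`, in this assay gives > 40000 nM, once more a limit.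

Compound 3 therefore stands nowhere in particular on the scale: its value is a limit, and it cannot be placed above or below the other two, whose values are limits as well. Among the measured compounds shown here, all that the three measurements share is the limit of > 40000 nM in this assay, at which 3 of the 3 values shown sit, so no step between measured compounds can be read, and no ordering exists.

Compound 4, `COC(=O)[C@@H]1C[C@@]23CN(C)C[C@@H](CCC4=C2[C@@H]1CC4=O)C31CC=C(C(C)C)OC1`, is the next compound and differs from compound 3 in one place: methyl in place of hydrogen on a saturated chain carbon bound to a double-bonded ring carbon and a saturated chain carbon. For the measured compounds named here, nothing among the measured compounds shows what such a change does, since every value so far is a limit.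

Without any measured step to lean on, the step from compound 3 to compound 4 in this assay is expected to be none beyond the scatter, which is what a step that the limit leaves unreadable from compound 3 to compound 4 means here. Compound 4 is expected to give 60000 nM, between 20000 nM and 200000 nM, most likely reported once more as a limit.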

Compound 4, half-maximal inhibitory concentration: > 40000 nM
Compound 4: a limit, no number; the forecaster's own chance of this, stated with the estimate: 85%; the middle value lies beyond the limit too.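

The step from compound 3 to compound 4 cannot be read, since both values are limits and not numbers: the limit of > 40000 nM in this assay, at which 4 of the 4 values shown sit.

The compounds shown leave open how strong any of them is in this assay and whether going from ethyl to isopropyl changes anything.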